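This account rests on a few compounds, and the source may have more. Where it says the series, first, only, none or still open, it means among the compounds named here.

Compound 1 `CCN1C(=O)CN(C2CCCC2)c2nc(Nc3ccc(N4CCN(C)CC4)cc3)ncc21` was examined in an ADME assay on HEK293 cells (Homo sapiens) for inhibition, read by MTT assay, with a stated time of 48 h; on this read-out higher numbers stand for weaker inhibition and lower numbers for stronger inhibition. In this assay compound 1 gives > 30000 nM, which is a limit of the assay and not a number. Compound 2 `CCN1C(=O)CN(C2CCCC2)c2nc(Nc3ccc(N4CCCCC4)cc3)ncc21` carries piperidin-1-yl in place of 4-methylpiperazin-1-yl on an aromatic carbon. In this assay compound 2 gives > 30000 nM, again a limit rather than a number. The step that the two limits leave unreadable from compound 1 to compound 2 is therefore unreadable. Compound 3 `CCN1C(=O)CN(C2CCCC2)c2nc(Nc3ccc(N4CCN(C)CC4)cn3)ncc21` is built on another core; the difference between the two cores is not broken down here. In this assay compound 3 gives > 30000 nM, once more a limit of the assay. All three values thus sit at the limit of > 30000 nM in this assay, at which 3 of the 3 values shown sit. Compound 4 `CCN1C(=O)CN(C2CCCC2)c2nc(Nc3ccc(N4CCCCC4)cn3)ncc21` is not yet measured and carries piperidin-1-yl in place of 4-methylpiperazin-1-yl on an aromatic carbon. The place is not the same as in compound 2: there the group sits on a six-membered aromatic ring of carbon only, here on a six-membered aromatic ring with 1 nitrogen, two atoms from the ring nitrogen, so this is the same kind of change, not the same change. Resting on compound 3 at the limit of > 30000 nM in this assay, at which 3 of the 3 values shown sit, and on the unreadable a step that the two limits leave unreadable from compound 1 to compound 2, the expected step is a step that the limit leaves unreadable from compound 3 to compound 4. Compound 4 is estimated at 60000 nM, between 20000 nM and 300000 nM, and most probably this assay will again report only a limit.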

Compound 4, half-maximal inhibitory concentration: > 30000 nM
Compound 4 was reported as a limit (the forecaster's own chance of this, stated with the estimate: 85%); the middle value is on the limit's open side.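

In this assay compound 4 gives > 30000 nM which is a limit of the assay and not a number. Going by these compounds alone, no step can therefore be read from compound 3 to compound 4. The compounds shown leave open whether piperidin-1-yl in place of 4-methylpiperazin-1-yl changes inhibition at all, because every value stands at the same limit: the limit of > 30000 nM in this assay, at which 4 of the 4 values shown sit.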